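This account rests on a few compounds, and the source may have more. Where it says the series, first, only, none or still open, it means among the compounds named here.

The two measured compounds share one core, a urea linking two aromatic rings, and differ only in one group on an aromatic carbon. Compound 1 `O=C(Nc1ccc(-n2ncc3c(Br)cccc32)cc1)Nc1ccc(Cl)c(C(F)(F)F)c1` gives 2000 nM in a functional assay on HepG2 cells (Homo sapiens) for cytotoxicity, read by MTT assay, with a stated time of 72 h; on this read-out lower numbers stand for stronger inhibition and higher numbers for weaker inhibition. Compound 2 `Cc1cccc2c1cnn2-c1ccc(NC(=O)Nc2ccc(Cl)c(C(F)(F)F)c2)cc1` gives 4000 nM in this assay, and the two numbers lie within the scatter of each other, as the step of a 2.0-fold higher number from compound 1 to compound 2 (0.30 log units; within the scatter) shows.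

Compound 3 `O=C(Nc1ccc(-n2ncc3cnccc32)cc1)Nc1ccc(Cl)c(C(F)(F)F)c1` is not yet measured. It differs from compound 2 in that (a group of 9 heavy atoms (6 carbon, 3 nitrogen; one five-membered aromatic ring with 2 hetero atoms, one six-membered aromatic ring with 1 hetero atom) in place of a group of 10 heavy atoms (8 carbon, 2 nitrogen; one five-membered aromatic ring with 2 hetero atoms, one six-membered aromatic ring of carbon only), on an aromatic carbon). Within the data shown here, the only measured step, that from compound 1 to compound 2, exchanges a small group at the same aromatic carbon and stays within the scatter, so it offers little guidance for a change that replaces the whole two-ring group. Among the measured compounds shown here, with no measured step that bears directly on this change, the estimate for compound 3 is set near compound 2 and is expected to be 4000 nM, within the range 1500 nM to 12000 nM. The expected step from compound 2 to compound 3 is therefore no change at the digits printed from compound 2 to compound 3 (within the scatter), with wide uncertainty.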

Compound 3, half-maximal inhibitory concentration: 4000 nM
Beside the measured number, compound 3's estimate shows no gap at the digits printed; low and high end bracket the measured number.
By their numbers in this assay, from the lowest: compounds 1, 2 and 3 (each within the scatter of the next).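

In this assay, exchanging the 4-methyl-1H-indazol-1-yl group for a two-ring group with a hetero atom in its six-membered ring gives no change at the digits printed from compound 2 to compound 3 (within the scatter), and the exchange starting from the bromo compound gives a 2.0-fold higher number from compound 1 to compound 3 (0.30 log units; within the scatter). Among these compounds, compound 1 and compound 2 showed only that a small group on this two-ring group could be exchanged, whereas compound 3 shows that a change within the ring itself, with one more hydrogen-bond acceptor, also stays within the scatter. Nothing measured here explains this result.

From the compounds shown here alone, all three compounds keep the same urea and the same chloro and trifluoromethyl groups, so what a change in those parts would do remains open. An amine or a carboxylic acid on the two-ring group might show whether a change here can ever produce a step beyond the scatter.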